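Trimming an Aryl Ether Chain: Ethoxy to Methoxy

The compounds below may be only part of what the source reports. "The series", "measured", "known", "first", "only" and "open" are said of these compounds alone.

Compound 1, `CCOc1c(-c2occ(C)c2CO)ccc2c1CCCC2(C)C`: 16.9 uM
Compound 2, `Cc1coc(-c2ccc3c(c2O)CCC3)c1C(=O)O`: 31.4 uM

Both compounds were tested in a functional assay on KB cells (Homo sapiens) for cytotoxicity, read by sulforhodamine B assay, with a stated time of 3 days; a higher number here means that more compound is needed for the effect, a lower number that less compound is needed. Compound 1 gives the lower of the two numbers, 16.9 uM, while compound 2 gives 31.4 uM; the two values lie within the scatter of each other, so no order between them can be read from this assay. Compound 3, `COc1c(-c2occ(C)c2CO)ccc2c1CCCC2(C)C`, has not yet been measured. It differs from compound 1 in one place: hydrogen in place of methyl on a saturated chain carbon bound to an oxygen on an aromatic ring. Among the compounds with values here, no measured pair shows this change, so its effect in this assay is unknown from the data at hand. Because compound 1 stands at 16.9 uM, compound 3 is expected to land near it, with a step of a 1.1-fold higher number from compound 1 to compound 3 (0.03 log units; within the scatter) and no direction beyond the scatter. Compound 3 is therefore estimated at 18 uM, in a range from 7 uM to 45 uM.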

Compound 3, concentration for half-maximal effect: 25.3 uM
Compound 3: the middle estimate sits 1.4-fold (0.15 log units) below what was measured; measured number inside the range.
By their numbers in this assay, from the lowest: compounds 1, 3 and 2 (each within the scatter of the next).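

Within the data shown here, this pair gives the first direct reading at this position, where the ethoxy of compound 1 becomes the methoxy of compound 3 on an otherwise unchanged core. In this assay the exchange of methyl for hydrogen on the saturated chain carbon bound to the aromatic oxygen appears as a 1.5-fold higher number from compound 1 to compound 3 (0.18 log units; within the scatter), so removing this one carbon gives no difference that the assay can separate from the scatter. Nothing measured here bears on why the two compounds read alike.

Going by these compounds, whether a longer chain such as propoxy, or a hydroxyl or an amine in place of the ether, would give a step beyond the scatter remains open. This pair also leaves open whether the same ethoxy to methoxy exchange would read alike on another core.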